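This account rests on a few compounds, and the source may have more. Where it says the series, first, only, none or still open, it means among the compounds named here.

Compound 1 `CC(C)(C)c1ccc(CNCCCNS(=O)(=O)c2cc(C(F)(F)F)cc(C(F)(F)F)c2)cc1` is the reference point of this small set. In a functional assay on HPAC cells (Homo sapiens) for inhibition, read by MTT assay, with a stated time of 72 h (on this read-out lower numbers stand for stronger inhibition of growth and higher numbers for weaker inhibition of growth), compound 1 gives 2300 nM, and the two other measured compounds sit close by: compound 2 `O=S(=O)(NCCCNCc1ccc(Br)cc1)c1cc(C(F)(F)F)cc(C(F)(F)F)c1` gives 2900 nM and compound 3 `O=S(=O)(NCCCNCc1cccc(Cl)c1)c1cc(C(F)(F)F)cc(C(F)(F)F)c1` gives 2700 nM. The steps of a 1.3-fold higher number from compound 1 to compound 2 (0.10 log units; within the scatter) and a 1.2-fold higher number from compound 1 to compound 3 (0.07 log units; within the scatter) both stay within the scatter, as does a 1.1-fold lower number from compound 2 to compound 3 (0.03 log units; within the scatter). Compound 4 `COc1cccc(CNCCCNS(=O)(=O)c2cc(C(F)(F)F)cc(C(F)(F)F)c2)c1` differs from compound 1 by 3-methoxyphenyl in place of 4-(tert-butyl)phenyl on a saturated chain carbon bound to an amine nitrogen. The two steps from compound 1 bear on this change, since each also swaps the group on the same saturated chain carbon, and neither moved the number beyond the scatter. Compound 4 is therefore expected to give about 2500 nM, between 1200 nM and 5200 nM. The expected step of a 1.1-fold higher number from compound 1 to compound 4 (0.04 log units; within the scatter) is estimated to stay within the scatter.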

Compound 4, concentration for 50% growth inhibition: 2400 nM
The estimate for compound 4 lay 1.0-fold (0.02 log units) above the measured number; measured number inside the range.
By their numbers in this assay, from the lowest: compounds 1, 4, 3 and 2 (each within the scatter of the next).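

In this assay, the number stays within the scatter when 3-methoxyphenyl, with one hydrogen-bond acceptor, replaces 4-(tert-butyl)phenyl, which has none: a 1.0-fold higher number from compound 1 to compound 4 (0.02 log units; within the scatter). The same holds for the swap of methoxy for chloro on an aromatic carbon, a 1.1-fold lower number from compound 3 to compound 4 (0.05 log units; within the scatter), and for 3-methoxyphenyl in place of 4-bromophenyl, a 1.2-fold lower number from compound 2 to compound 4 (0.08 log units; within the scatter). Nothing available explains this lack of separation.

All four compounds carry a substituted phenyl group at this position. Going by these compounds, whether a carboxylic acid on that ring, a pyridine ring in its place or a longer chain would move the number beyond the scatter remains open.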